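Methylsulfonyl to tert-butyl on the pendant aromatic ring

The source may report more compounds than this note shows. Statements on the series, on what has been measured and on what is new or still open speak of the compounds shown alone.

Three compounds of the series have a number in a physicochemical assay for lipophilicity, read by HPLC, measured as chromatographic lipophilicity, at pH 7.4; on this read-out higher numbers stand for higher lipophilicity and lower numbers for lower lipophilicity. Compound 1 `CC(C)(C)C(=O)N1N=CCC1c1ccc(S(C)(=O)=O)cc1` gives 4.1 and stands second highest of the three. Compound 3 `O=C(c1ccccc1)N1N=CCC1c1ccccc1` gives 4.6, a number above compound 1 by a gap beyond the scatter, and compound 2 `CCC(=O)N1CCC(C(=O)N2N=CCC2c2ccccc2)CC1` gives 3.2, the lowest, further from compound 1 than compound 3 is. No two of these compounds differ in a single place, so no measured step is available to anchor the change that follows.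

Compound 4 `CC(C)(C)C(=O)N1N=CCC1c1ccc(C(C)(C)C)cc1` is not yet measured in this assay. It differs from compound 1 as follows: tert-butyl in place of methylsulfonyl on an aromatic carbon. What the measured numbers offer is only the position of compound 1 within the set; they do not contain a comparable exchange.

The expectation for the step from compound 1 to compound 4 in this assay is a clear rise, well beyond the scatter, a number 2.90 log units higher from compound 1 to compound 4 (beyond the scatter). Compound 4 is accordingly estimated at 7, with a range from 6.2 to 7.8.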

Compound 4, distribution coefficient: 8
Estimate against measurement, compound 4: 1.00 log units below; the whole stated range lies below it.
By their numbers in this assay, from the lowest: compound 2; then compound 1; then compound 3; then compound 4.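

In this assay, among these compounds, tert-butyl in place of methylsulfonyl on the aromatic carbon gives the first single-place step, a number 3.90 log units higher from compound 1 to compound 4 (beyond the scatter), and that step is large. It shows that this position is far from silent on this read-out: the groups exchanged both hold 4 heavy atoms, yet the 2 hydrogen-bond acceptors that leave are replaced by none, and the number moves well beyond the scatter. Nothing measured here accounts for the size of this step.

On these data alone, what an amine or a carboxylic acid would give on the same aromatic carbon stays open. Also open, as far as these compounds go, is whether the same exchange gives a step of similar size on the cores of compound 2 and compound 3.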